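This account rests on a few compounds, and the source may have more. Where it says the series, first, only, none or still open, it means among the compounds named here.

Among the measured compounds shown here, in a functional assay on DU-145 cells (Homo sapiens) for cytotoxicity, read by trypan blue exclusion, with a stated time of 96 h (a lower number here means a stronger inhibitor, a higher number a weaker inhibitor), compound 3 (`COc1cc(OC)c(/C=C/S(=O)(=O)Nc2ccc(OC)c(NC(C(=O)O)c3ccc(F)cc3)c2)c(OC)c1`) gives 75 nM, the lowest number of the three measured so far. Compound 1 (`COc1cc(OC)c(/C=C/S(=O)(=O)Nc2ccc(OC)c(F)c2)c(OC)c1`) gives 200 nM, and compound 2 (`COC(=O)C(Nc1cc(NS(=O)(=O)/C=C/c2c(OC)cc(OC)cc2OC)ccc1OC)c1ccc(Cl)cc1`) gives 5000 nM. Compound 4 (`COc1cc(OC)c(/C=C/S(=O)(=O)Nc2ccc(OC)c(NC(C(=O)O)c3ccc(Br)cc3)c2)c(OC)c1`) has bromo in place of fluoro on an aromatic carbon, para to a large group (bromo in place of fluoro on an aromatic carbon). For the measured compounds named here, two measured steps bear on this only indirectly. The modest 2.7-fold lower number from compound 1 to compound 3 (0.43 log units; beyond the scatter) replaces fluoro with a whole substituted amino group. The large 67-fold lower number from compound 2 to compound 3 (1.82 log units; beyond the scatter) alters the methoxycarbonyl group along with the halogen. Neither isolates this exchange, so no step beyond the scatter is expected in this assay. The expected change is a 1.1-fold higher number from compound 3 to compound 4 (0.03 log units; within the scatter). Compound 4 is estimated at 80 nM, within a range of 30 nM to 220 nM.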

Compound 4, half-maximal inhibitory concentration: 250 nM
Compound 4: the middle estimate sits 3.1-fold (0.49 log units) below what was measured, outside the stated range (above it).
By their numbers in this assay, from the lowest: compound 3; then compounds 1 and 4 (each within the scatter of the next); then compound 2.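

In this assay the halogen on this ring proves not to be interchangeable: bromo in place of fluoro, para to a large group, alone gives a 3.3-fold higher number from compound 3 to compound 4 (0.52 log units; beyond the scatter) and so reverses the earlier gain. That gain over the fluoro of the shared core disappears with bromo, as the whole ((4-bromophenyl)(carboxy)methyl)amino group gives a 1.3-fold higher number from compound 1 to compound 4 (0.10 log units; within the scatter), while a 20-fold lower number from compound 2 to compound 4 (1.30 log units; beyond the scatter) remains large. No measurement shown here accounts for the effect of this exchange.

On these data alone, whether chloro, methyl or methoxy at this place, with the carboxylic acid kept, would track fluoro or bromo stays open. As far as these compounds go, how much of the gap to compound 2 belongs to its methoxycarbonyl group alone also stays open.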